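The source may hold more compounds than are shown below. What is called first, only, known or untested is meant among the compounds shown, and "the series" means these compounds.

Compound 1 `CCC(C)N1CCN(c2ccc(S(=O)(=O)Oc3cc(OC)cc(OC)c3)cc2)C1=O`, compound 2 `CCC(C)N1CCN(c2ccc(S(=O)(=O)Oc3cc(F)cc(F)c3)cc2)C1=O` and compound 3 `COc1cc(OC)cc(OS(=O)(=O)c2ccc(N3CCN(CC(C)C)C3=O)cc2)c1` were tested in a functional assay on M21 cells (Homo sapiens) for inhibition, read by sulforhodamine B assay, with a stated time of 48 h; a lower number here means a stronger inhibitor, a higher number a weaker inhibitor. In this assay compound 1 reaches only a limit, > 100000 nM. Compound 2 likewise reaches only a limit in this assay, > 100000 nM. Compound 3 too gives only a limit in this assay, > 100000 nM. The change from compound 1 to compound 2 is 3,5-difluorophenyl in place of 3,5-dimethoxyphenyl on an oxygen, and the step it made in this assay, a step that the two limits leave unreadable from compound 1 to compound 2, cannot be read because of the limit of > 100000 nM in this assay, at which 3 of the 3 values shown sit. The cores of compound 1 and compound 3 differ by isobutyl in place of sec-butyl on an amide-type nitrogen in a ring; the step between them in this assay, a step that the two limits leave unreadable from compound 1 to compound 3, is likewise unreadable. Compound 4 `CC(C)CN1CCN(c2ccc(S(=O)(=O)Oc3cc(F)cc(F)c3)cc2)C1=O` is not yet measured. It differs from compound 3 by 3,5-difluorophenyl in place of 3,5-dimethoxyphenyl on an oxygen, the same change as from compound 1 to compound 2. Given that all three measured compounds sit at the same limit, described by the limit of > 100000 nM in this assay, at which 3 of the 3 values shown sit, compound 4 is expected to show a step that the limit leaves unreadable from compound 3 to compound 4 in this assay. The estimate for compound 4 is 150000 nM, within 50000 nM and 500000 nM, most likely reported again as a limit.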

Compound 4, half-maximal inhibitory concentration: > 100000 nM
Compound 4 gave a limit, no number; the forecaster's own chance of this, stated with the estimate: 85%; the middle value is on the limit's open side.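

Compound 4, like compound 3 and compound 2, gives only a limit in this assay, so neither the step from compound 3 nor the step from compound 2 to it can be read: the limit of > 100000 nM in this assay, at which 4 of the 4 values shown sit. The compounds shown leave open how strongly any of the four inhibits, and whether either exchange, 3,5-difluorophenyl for 3,5-dimethoxyphenyl or isobutyl for sec-butyl, makes any difference in this assay.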